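This account rests on a few compounds, and the source may have more. Where it says the series, first, only, none or still open, it means among the compounds named here.

Measured compounds:

- Compound 1, `CC(=O)c1cc(-c2ccc(F)cc2)cc2cc(-c3ccccc3)[nH]c12`, gives 90.3% in a functional assay on HeLa cells (Homo sapiens) for cytotoxicity, read by MTT assay, with a stated time of 2 days, tested at 0.1 uM; on this read-out higher numbers stand for a weaker effect at the one concentration tested and lower numbers for a stronger effect.
- Compound 2, `CC(=O)c1cc(-c2ccc(F)cc2)cc2cc(-c3ccc(F)cc3)[nH]c12`, gives 90.1% in this assay.
- Compound 3, `COc1ccc(-c2cc3cc(-c4ccccc4)cc(C(C)=O)c3[nH]2)cc1`, gives 80.5% in this assay.

Of these three numbers, compound 3 shows the lowest one, yet its gaps to compound 2 and to compound 1 both lie within the usual scatter of this kind of measurement, so the three compounds cannot be told apart on the read-out shown; none of them can be called stronger or weaker than the others.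

Compound 4, `COc1ccc(-c2cc3cc(-c4ccc(F)cc4)cc(C(C)=O)c3[nH]2)cc1`, has not yet been measured. Compared with compound 3 it carries one change: fluoro in place of hydrogen on an aromatic carbon. The same change has been made once before among the measured compounds, namely the step of a number 0.2 percentage points lower from compound 1 to compound 2 (within the scatter), and there it brought no shift beyond the scatter.

Within the data shown here, with only that one precedent to go on, the expectation is that the step from compound 3 to compound 4 will likewise stay within the scatter, in no particular direction: a number 0.5 percentage points lower from compound 3 to compound 4 (within the scatter) is the estimated step. For compound 4 in this assay the estimated value is therefore 80%, with a range from 70% to 91%.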

Compound 4, a percentage reported as activity, at one concentration (the size of the read-out at that concentration, not a potency): 81%
Compound 4: middle estimate off by 1 percentage points, on the low side; measured number inside the range.
By their numbers in this assay, from the lowest: compounds 3, 4, 2 and 1 (each within the scatter of the next).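

The phenyl to 4-fluorophenyl change now has a second case, on a core that carries methoxy, and in this assay it again leaves the read-out unmoved, with a number 0.5 percentage points higher from compound 3 to compound 4 (within the scatter). Two cases on different cores give the first sign that this change behaves alike on both, though each is small enough to be scatter alone: the same change on two cores in this assay, a number 0.2 percentage points lower (within the scatter) from compound 1 to compound 2 and a number 0.5 percentage points higher (within the scatter) from compound 3 to compound 4, 0.7 percentage points apart, within the scatter of two such steps

Compound 4 also completes two further comparisons on its own core, with a number 9.1 percentage points lower from compound 2 to compound 4 (within the scatter) where methoxy takes the place of fluoro and a number 9.3 percentage points lower from compound 1 to compound 4 (within the scatter) where methoxy takes the place of hydrogen, so on this read-out methoxy cannot be separated from either.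

From the compounds shown here alone, all four compounds lie within the scatter of one another, and only hydrogen, fluoro and methoxy appear on these rings, so it remains open whether any change at these places can move the number at all. Whether an amine, a carboxylic acid or a longer chain in the same place would give a step beyond the scatter is something these compounds cannot tell.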